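Phenoxy for tert-butyl on an aryl imidazoline oxadiazole

A few compounds are considered here, and "the series" means these few. Any claim that something is new, unique, unknown or untested is made for them only; others in the source may bear on it.

Of the compounds shown here, two have been measured so far. Compound 1 `c1cc(-c2noc(C3CC3)n2)ccc1C1=NCCN1` gives 4280 nM in an assay for inhibition of Amine oxidase [flavin-containing] B (Homo sapiens), read by fluorescence and spectrophotometry, using microsomes, with stated times of 30 min and 20 min; a lower number here means a stronger inhibitor, a higher number a weaker inhibitor. Compound 2 `CC(C)(C)c1ccc(-c2noc(-c3ccc(C4=NCCN4)cc3)n2)cc1` gives 411 nM in the same assay, the lower of the two numbers, with compound 1 standing a good deal higher, a gap that lies beyond the usual scatter. Compound 3 `c1ccc(Oc2ccc(-c3noc(-c4ccc(C5=NCCN5)cc4)n3)cc2)cc1` has not yet been measured. It differs from compound 2 in one place, phenoxy in place of tert-butyl on an aromatic carbon. Among the compounds with values here, no single-change step between measured compounds is available to guide this change, so the expectation rests on the fact that compound 2 with its larger aryl group already sits at 411 nM. The author expects the step of a 1.4-fold lower number from compound 2 to compound 3 (0.14 log units; within the scatter) to be small, downward if anything, and not clearly beyond the scatter. For compound 3 the estimate is 300 nM, within a range from 80 nM to 1200 nM.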

Compound 3, half-maximal inhibitory concentration: 1370 nM
Compound 3: the middle estimate sits 4.6-fold (0.66 log units) below what was measured; the measured number lies above the stated range.
By their numbers in this assay, from the lowest: compound 2; then compound 3; then compound 1.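

In this assay the change from tert-butyl to phenoxy, on an aromatic carbon para to a large group, brings a 3.3-fold higher number from compound 2 to compound 3 (0.52 log units; beyond the scatter) and is a modest step beyond the usual scatter. Within the data shown here, this position therefore responds to what it carries, which the earlier compounds alone could not show. In this one pair the larger group, with its added ring and hydrogen-bond acceptor, gives the higher number, and nothing available speaks to the reason for the step.

Because the ring and its linking oxygen enter together, the pair cannot say which of them goes with the higher number. On these data alone, a methoxy group, which keeps the oxygen without the ring, and a directly attached phenyl, which keeps the ring without the oxygen, remain open at this position.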